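Swapping a cyclopropyl group on a carbonyl carbon

The compounds below may be only part of what the source reports. "The series", "measured", "known", "first", "only" and "open" are said of these compounds alone.

In a physicochemical assay for solubility, read by HPLC, in phosphate buffer, measured as kinetic solubility, at pH 7.4 (on this read-out lower numbers stand for lower solubility and higher numbers for higher solubility), compound 1 (`CCC(=O)c1cc(-c2ccc(OC)cc2)n(-c2ccc(S(N)(=O)=O)cc2)c1C`) gives 12800 nM and compound 2 (`NS(=O)(=O)c1ccc(-c2cc(C(=O)C3CC3)nn2-c2ccc(Cl)cc2)cc1`) gives 25600 nM and these two values lie within the usual scatter of repeated measurements. Compound 2 therefore cannot be ranked apart from compound 1. The two also differ in more than one place, so they offer no clean single-change comparison.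

Compound 3 (`NS(=O)(=O)c1ccc(-c2cc(C(=O)N3CC4CC4C3)nn2-c2ccc(Cl)cc2)cc1`) departs from compound 2 in one place, on a carbonyl carbon (a group of 6 heavy atoms (5 carbon, 1 nitrogen; one three-membered non-aromatic ring of carbon only, one five-membered non-aromatic ring with 1 hetero atom) in place of a group of 3 heavy atoms (3 carbon; one three-membered non-aromatic ring of carbon only), on a carbonyl carbon) where the cyclopropyl gives way to a larger group. For the measured compounds named here, no measured pair shows what such a swap does. The expected change is none beyond the scatter (a 1.4-fold lower number from compound 2 to compound 3 (0.15 log units; within the scatter)) and that expectation is loose. It starts from compound 2 at 25600 nM as the nearest measured structure. The expected value for compound 3 is 18000 nM with 6000 nM and 50000 nM as the estimated ends of its range.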

Compound 3, solubility: 36600 nM
Estimate against measurement, compound 3: 2.0-fold (0.31 log units) below; low and high end bracket the measured number.
By their numbers in this assay, from the lowest: compounds 1, 2 and 3 (each within the scatter of the next, the first and the last beyond it).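

In this assay, for the compounds shown here, the swap on the carbonyl carbon gives the first single-change reading at this position: the step is a 1.4-fold higher number from compound 2 to compound 3 (0.16 log units; within the scatter) and so compound 3 cannot be told apart from compound 2. At this position, then, cyclopropyl can give way to a group of 6 heavy atoms, with a nitrogen and a second ring, without a difference that stands clear of the usual scatter of repeated measurements, though this rests on a single pair. Nothing measured here offers a reason for this result.

As far as these compounds go, it stays open whether a simple amine, a carboxylic acid or a longer chain on this carbonyl carbon would move the number beyond the scatter. Also open, from the compounds shown here alone, is whether the same swap would read alike on the core of compound 1.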